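The compounds below may be only part of what the source reports. "The series", "measured", "known", "first", "only" and "open" are said of these compounds alone.

Compound 3 `COc1cc(N2C(N)=C(C#N)C(c3ccc(C)o3)C3=C2CC(C)(C)CC3=O)cc(OC)c1OC` gives 31% in a functional assay on Ehrlich cells (Mus musculus) for cytotoxicity, tested at 25 ug/mL (on this read-out lower numbers stand for a weaker effect and higher numbers for a stronger effect at the one concentration tested), the highest of the three numbers recorded. Compound 1 `COc1ccc(C2C(C#N)=C(N)N(c3cc(OC)c(OC)c(OC)c3)C3=C2C(=O)CC(C)(C)C3)cc1` gives 1% and compound 2 `COc1cc(N2C(N)=C(C#N)C(c3ccccc3O)C3=C2CC(C)(C)CC3=O)cc(OC)c1OC` gives 0%; the step of a number 1 percentage points lower from compound 1 to compound 2 (within the scatter) leaves the two of them level with each other. Against these, the steps of a number 30 percentage points higher from compound 1 to compound 3 (beyond the scatter) and a number 31 percentage points higher from compound 2 to compound 3 (beyond the scatter) set compound 3 apart.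

Compound 4 `COc1cc(N2C(N)=C(C#N)C(c3ccccc3)C3=C2CC(C)(C)CC3=O)cc(OC)c1OC` differs from compound 3 in one place: phenyl in place of 5-methylfuran-2-yl on a saturated ring carbon. All three measured steps concern an exchange of the group on this same saturated ring carbon. The two that lead to compound 3 show the 5-methylfuran-2-yl group going with the higher number, while the exchange between two six-membered aromatic rings of carbon, a number 1 percentage points lower from compound 1 to compound 2 (within the scatter), stayed within the scatter. Replacing the 5-methylfuran-2-yl group with phenyl is therefore expected to undo most of that rise, an expected step of a number 26 percentage points lower from compound 3 to compound 4 (beyond the scatter). Compound 4 is accordingly estimated at 5%, with a range from 0% to 20%.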

Compound 4, a percentage reported as activity, at one concentration (the size of the read-out at that concentration, not a potency): 6%
The estimate for compound 4 lay 1 percentage points below the measured number; measured number inside the range.
By their numbers in this assay, from the lowest: compounds 2, 1 and 4 (each within the scatter of the next); then compound 3.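

In this assay, within the data shown here, compound 4 supplies the unsubstituted phenyl reference that the earlier compounds lacked: a number 6 percentage points higher from compound 2 to compound 4 (within the scatter) and a number 5 percentage points higher from compound 1 to compound 4 (within the scatter), so neither the hydroxy nor the methoxy group on that ring shifts the number beyond the scatter. At this saturated ring carbon, the separation therefore follows the exchange of the ring itself, with a number 25 percentage points lower from compound 3 to compound 4 (beyond the scatter) when phenyl replaces 5-methylfuran-2-yl, and it does not depend on those two substituents. No measurement is at hand that could explain this step.

On these data alone, what a plain furan-2-yl group would give at this carbon remains open, so the share of the ring and the share of its methyl group in the step cannot be separated. As far as these compounds go, whether a thiophene-2-yl or pyridin-2-yl group would read like the 5-methylfuran-2-yl group or like phenyl also remains open.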